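The source may report more compounds than this note shows. Statements on the series, on what has been measured and on what is new or still open speak of the compounds shown alone.

Compound 2 `CCCc1ncc2cnnc(O)n12` stands only at a limit in a functional assay for inhibition, with Homo sapiens as the target; on this read-out higher numbers stand for weaker inhibition and lower numbers for stronger inhibition. In this assay compound 2 gives > 48000 nM, a limit of the assay rather than a number. Compound 1 `CCCc1ncc2cnnc(S)n12` likewise gives > 48000 nM in this assay, again a limit. Compound 3 `CCCc1nc(C)c2cnnc(O)n12` gives 56800 nM in this assay, a measured number. The step that the two limits leave unreadable from compound 1 to compound 2 and the step that the limit leaves unreadable from compound 2 to compound 3 both remain unreadable due to the limit of > 48000 nM in this assay, at which 2 of the 3 values shown sit, so neither offers a readable size. Compound 4 `CC(C)(C)c1ncc2cnnc(O)n12` is not yet measured in this assay; it differs from compound 2 by tert-butyl in place of propyl on an aromatic carbon. Among the measured compounds shown here, no measured step alters the group at that carbon of the shared core, so the two measured steps give no direct guide, and all three measured values stay at or near the same limit. For compound 4 the value in this assay is therefore expected at 60000 nM, with a range from 30000 nM to 150000 nM. The step that the limit leaves unreadable from compound 2 to compound 4 is expected to stay within the scatter, and a further limit is the likelier outcome.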

Compound 4, half-maximal inhibitory concentration: > 48000 nM
Compound 4 was reported as a limit (the forecaster's own chance of this, stated with the estimate: 70%); the middle value lies beyond the limit too.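

No size can be read for the step from propyl in compound 2 to tert-butyl in compound 4, because both compounds stand only at a limit: the limit of > 48000 nM in this assay, at which 3 of the 4 values shown sit.

The compounds shown leave open whether these two groups on that aromatic carbon differ at all in inhibition.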